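Iodo in place of trifluoromethyl on compound 3

The compounds below may be only part of what the source reports. "The series", "measured", "known", "first", "only" and "open" are said of these compounds alone.

Values in a functional assay on PC-3 cells (Homo sapiens) for cytotoxicity, read by MTT assay (a lower number here means a stronger inhibitor, a higher number a weaker inhibitor), so far:
compound 1 `Oc1ccc(CN(Cc2ccccc2)Cc2ccc(O)c3ncccc23)c2cccnc12` gives 258 nM
compound 2 `Oc1ccc(CN(Cc2ccccc2C(F)(F)F)Cc2ccc(O)c3ncccc23)c2cccnc12` gives 179 nM
compound 3 `Oc1ccc(CN(Cc2cccc(C(F)(F)F)c2)Cc2ccc(O)c3ncccc23)c2cccnc12` gives 37 nM

Compound 3 has the lowest number of the three, and its steps to both others lie beyond the scatter. Compound 4 `Oc1ccc(CN(Cc2cccc(I)c2)Cc2ccc(O)c3ncccc23)c2cccnc12` has iodo in place of trifluoromethyl on an aromatic carbon, meta to a large group (iodo in place of trifluoromethyl on an aromatic carbon). Within the data shown here, two measured steps bear on this change: a 7.0-fold lower number from compound 1 to compound 3 (0.84 log units; beyond the scatter), and a 4.8-fold lower number from compound 2 to compound 3 (0.68 log units; beyond the scatter). Neither involves iodo, so the size of the swap itself is unmeasured. Iodo stays on the same aromatic carbon, so only a small rise is expected, and part of the first step may be given back. The expected step is a 1.4-fold higher number from compound 3 to compound 4 (0.13 log units; within the scatter), which would not go beyond the scatter. For compound 4 the estimate is 50 nM, with an expected range of 18 nM to 140 nM.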

Compound 4, half-maximal inhibitory concentration: 394 nM
Compound 4: the middle estimate sits 7.9-fold (0.90 log units) below what was measured, outside the stated range (above it).
By their numbers in this assay, from the lowest: compound 3; then compounds 2, 1 and 4 (each within the scatter of the next, the first and the last beyond it).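

In this assay, the drop in number that trifluoromethyl brought at this aromatic carbon does not carry over to iodo: the swap gives an 11-fold higher number from compound 3 to compound 4 (1.03 log units; beyond the scatter), and against hydrogen on the same carbon iodo gives a 1.5-fold higher number from compound 1 to compound 4 (0.18 log units; within the scatter). So the outcome at this position depends on which group enters, not merely on the carbon being substituted, and the 3-iodophenyl compound also falls behind the 2-(trifluoromethyl)phenyl compound, with a 2.2-fold higher number from compound 2 to compound 4 (0.34 log units; beyond the scatter). No measurement at hand explains the gap between trifluoromethyl and iodo. Going by these compounds, whether chloro, bromo or nitrile on this same carbon would track trifluoromethyl or iodo stays open.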